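Aminothiophene in Place of Pyridine on the Enone Carbonyl

The source may report more compounds than this note shows. Statements on the series, on what has been measured and on what is new or still open speak of the compounds shown alone.

Compound 3 `COc1ccc(-c2cc3ccccc3nc2/C=C/C(=O)c2ccccn2)cc1` stands at the low end of the three compounds measured in a functional assay on NCI-H1299 cells (Homo sapiens) for antiproliferative activity, read by XTT assay, with a stated time of 72 h (on this read-out higher numbers stand for weaker inhibition and lower numbers for stronger inhibition), where compound 3 gives 660 nM. Compound 1 `COc1ccc(C(=O)/C=C/c2nc3ccccc3cc2-c2ccc(OC)cc2)cc1` gives 6420 nM and compound 2 `COc1ccc(-c2cc3ccccc3nc2/C=C/C(=O)c2c(OC)cccc2OC)cc1` gives 4710 nM. The steps of a 9.7-fold lower number from compound 1 to compound 3 (0.99 log units; beyond the scatter) and a 7.1-fold lower number from compound 2 to compound 3 (0.85 log units; beyond the scatter) both lie beyond the scatter, while a 1.4-fold lower number from compound 1 to compound 2 (0.13 log units; within the scatter) does not, so compound 3 is the most potent of the three. Compound 4 `COc1ccc(-c2cc3ccccc3nc2/C=C/C(=O)c2sccc2N)cc1` differs from compound 3 in a single place: 3-aminothiophen-2-yl in place of pyridin-2-yl on a carbonyl carbon. The two measured steps that bear on this place both concern the group on the carbonyl carbon, and both gave a lower number when pyridin-2-yl entered; nothing measured here covers a five-membered aromatic ring or a hydrogen-bond donor at that place. Within the data shown here, the exchange of pyridin-2-yl for 3-aminothiophen-2-yl therefore has no direct precedent, and a step of modest size in either direction, or none beyond the scatter, is plausible. Compound 4 is expected to remain near the number of compound 3, with an estimated step of a 1.4-fold higher number from compound 3 to compound 4 (0.13 log units; within the scatter). Compound 4 is thus estimated at 900 nM, with a range from 300 nM to 3000 nM.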

Compound 4, half-maximal inhibitory concentration: > 10000 nM
Compound 4 gave a limit, no number; the forecaster's own chance of this, stated with the estimate: 3%; middle value at least 11-fold (1.04 log units) away from the limit.
By their numbers in this assay, from the lowest: compound 3; then compounds 2 and 1 (each within the scatter of the next). At a limit, above all of these: compound 4.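

In this assay compound 4 gives no number but a limit, > 10000 nM. The place on the carbonyl carbon proves sharply sensitive to which ring it carries, even though the heavy-atom count stays the same: an at least 15-fold higher number from compound 3 to compound 4 (1.18 log units; beyond the scatter) is a large step, while an at least 2.1-fold higher number from compound 2 to compound 4 (0.32 log units; beyond the scatter) also lies beyond the scatter and an at least 1.5-fold higher number from compound 1 to compound 4 (0.19 log units; that floor lies within the scatter) has a floor within it, so the low number of compound 3 is not held by every heteroaromatic ring at this place. All three steps are floors rather than full sizes, and they rest on one limit: the limit of > 10000 nM in this assay, at which 1 of the 4 values shown sits.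

Compound 4 brings in a five-membered ring, sulfur and an amine hydrogen-bond donor together, so the compounds shown do not say which of these goes with the loss, and a plain thiophen-2-yl or an aminopyridinyl group on the carbonyl carbon would separate them. Going by these compounds, how far the true value of compound 4 lies past its limit also stays open.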